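Shortening the alkoxy chain on a hydroxychalcone core

The compounds below may be only part of what the source reports. "The series", "measured", "known", "first", "only" and "open" are said of these compounds alone.

Compound 1, `CCCCCCOc1cccc(O)c1C(=O)/C=C/c1ccc(O)cc1`, gives in a functional assay on ACHN cells (Homo sapiens) for antiproliferative activity, read by sulforhodamine B assay; a higher number here means a weaker inhibitor of growth, a lower number a stronger inhibitor of growth > 30000 nM, which is a limit of the assay and not a number.
Compound 2, `O=C(/C=C/c1ccc(O)cc1)c1c(O)cccc1OCCC1CCCCC1`, gives in this assay > 30000 nM, again a limit of the assay.

On the numbers shown, compound 1 therefore stands only at a limit, with no number of its own. Going by the values given here, the single measured step, a step that the two limits leave unreadable from compound 1 to compound 2, cannot be read because of the limit of > 30000 nM in this assay, at which 2 of the 2 values shown sit. Compound 3, `CCCCOc1cccc(O)c1C(=O)/C=C/c1ccc(O)cc1`, differs from compound 1 by hydrogen in place of ethyl on a saturated chain carbon, four bonds along the chain from an oxygen on an aromatic ring. Among the compounds with values here, no measured step bears on this change, and the one step available is unreadable, so no movement beyond the scatter can be expected in either direction. Compound 3 is thus expected to give about 40000 nM in this assay, within a range of 15000 nM to 100000 nM, most probably reported once more as a limit. The step that the limit leaves unreadable from compound 1 to compound 3 implied by this estimate is expected to stay within the scatter.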

Compound 3, concentration for 50% growth inhibition: > 30000 nM
Compound 3 ended at the assay's limit; the forecaster's own chance of this, stated with the estimate: 80%; the middle value is on the limit's open side.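

No new step can be read among compound 1, compound 2 and compound 3 in this assay, because each stands at a limit of the assay and not at a number: the limit of > 30000 nM in this assay, at which 3 of the 3 values shown sit.
The compounds shown leave open how the different chains on the shared core compare in this assay.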